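Phenoxy in Place of Dimethylamino on a Shared Core

The source may hold more compounds than are shown below. What is called first, only, known or untested is meant among the compounds shown, and "the series" means these compounds.

Measured so far:
- compound 1 `CC(C)N(Cc1cccc(OCCCCCC(=O)O)c1)C(=O)c1ccc(-c2cccc(N(C)C)c2)cc1`, which in an ADME assay on HepG2 cells (Homo sapiens) for cytotoxicity, read by CellTiter-Glo and resazurin assay, with a stated time of 72 h (on this read-out higher numbers stand for an effect only at larger amounts of compound and lower numbers for an effect already at smaller amounts), gives > 26000 nM
- compound 2 `CC(C)N(Cc1cccc(OCCCCCC(=O)O)c1)C(=O)c1ccccc1`, which in this assay gives > 26000 nM

The value of compound 1 is a limit of the assay, not a number. The value of compound 2 is likewise a limit and not a number. Going by the values given here, the one step between measured compounds, a step that the two limits leave unreadable from compound 1 to compound 2, cannot be read because the limit of > 26000 nM in this assay, at which 2 of the 2 values shown sit, holds both of its ends. Compound 1 therefore stands at the limit of the assay, where every value shown sits, as the limit of > 26000 nM in this assay, at which 2 of the 2 values shown sit, records.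

Compound 3 `CC(C)N(Cc1cccc(OCCCCCC(=O)O)c1)C(=O)c1ccc(-c2cccc(Oc3ccccc3)c2)cc1` differs from compound 1 by phenoxy in place of dimethylamino on an aromatic carbon. No measured step touches a phenoxy group, so there is nothing that would point to a step in either direction beyond the scatter, and the only step shown is unreadable. The expectation for compound 3 in this assay is a step of a number no higher from compound 1 to compound 3 (the limit leaves the size open), that is, no readable change. Compound 3 is thus estimated at 26000 nM, with a range from 13000 nM to 60000 nM, and most likely the assay would again report only a limit.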

Compound 3, half-maximal effective concentration: > 18700 nM
Compound 3 was reported as a limit; the forecaster's own chance of this, stated with the estimate: 80%; the middle value does not contradict the limit.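

In this assay compound 3 gives > 18700 nM, which is a limit of the assay and not a number. Compound 1 gives > 26000 nM, likewise a limit. Going by these compounds alone, no step from compound 1 to compound 3 can therefore be read. Open stays whether phenoxy in place of dimethylamino changes anything in this assay, and at what amount any of these compounds would show an effect.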